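The compounds below may be only part of what the source reports. "The series", "measured", "known", "first", "only" and "open" are said of these compounds alone.

Measured in a functional assay on IMR-32 cells (Homo sapiens) for antiproliferative activity, read by MTT assay; on this read-out lower numbers stand for stronger inhibition and higher numbers for weaker inhibition:
compound 1 `CC(=O)c1ccc(-n2cc(COc3ccc(/C=C/C(=O)c4cc5c(cc4O)OC(C)(C)CC5)cc3)nn2)cc1`: "not active" (no number reported)
compound 2 `CCc1ccccc1-n1cc(COc2ccc(/C=C/C(=O)c3cc4c(cc3O)OC(C)(C)CC4)cc2)nn1`: "not active" (no number reported)
compound 3 `COc1ccc(-n2cc(COc3ccc(/C=C/C(=O)c4ccc5c(c4O)CCC(C)(C)O5)cc3)nn2)c([N+](=O)[O-])c1`: 132000 nM

Among the measured compounds shown here, compound 3, at 132000 nM, holds the only number, so it cannot be ranked against compound 1 or compound 2, neither of which has a number. Compound 4 `CCCCCn1cc(COc2ccc(/C=C/C(=O)c3ccc4c(c3O)CCC(C)(C)O4)cc2)nn1` carries pentyl in place of 4-methoxy-2-nitrophenyl on an aromatic nitrogen. For the measured compounds named here, no measured step in this assay covers this change, so the expectation is weakly founded: a modest step towards stronger inhibition, possibly none beyond the scatter. The expected change is a 1.9-fold lower number from compound 3 to compound 4 (0.28 log units; within the scatter). For compound 4 the estimated value is 70000 nM, with an expected range from 15000 nM to 250000 nM.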

Compound 4, half-maximal inhibitory concentration: "not active" (no number reported)
For compound 4 the study gives words and no number; no gap can be computed for the estimate.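

Among the compounds shown here, compound 4 is reported in words without a number, and no step from compound 3 can be read. From the compounds shown here alone, how pentyl compares with 4-methoxy-2-nitrophenyl on the read-out stays open. No evidence shown bears on this result.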